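Predicting a difluoro-methoxybenzyl variant of compound 1

This account rests on a few compounds, and the source may have more. Where it says the series, first, only, none or still open, it means among the compounds named here.

Compound 1 `COc1ccc(N2C(=O)N(Cc3ccc(F)cc3Cl)c3ccccc3S2(=O)=O)cc1OC` is the weakest binder among the three measured compounds: in an assay on HEK293 cells for displacement of a labelled ligand from Orexin receptor type 2 (Homo sapiens), read by scintillation counting, with a stated time of 90 min (a higher number here means a weaker inhibitor, a lower number a stronger inhibitor), compound 1 gives 25.1 nM. Compound 2 `COc1cc(F)c(CN2C(=O)N(c3ccc(OC)c(OC)c3)S(=O)(=O)c3ccccc32)c(Cl)c1` gives 0.1 nM in this assay. Compound 3 `COc1cc(N2C(=O)N(Cc3c(F)cc(F)cc3F)c3ccccc3S2(=O)=O)cc(OC)n1` differs from compound 1 in more than one place, and in this assay compound 3 gives 1.26 nM. Going by the values given here, the only single-place step on record is a 250-fold lower number from compound 1 to compound 2 (2.40 log units; beyond the scatter), a very large gain in binding strength from one change on the benzyl group.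

Compound 4 `COc1ccc(N2C(=O)N(Cc3c(F)cc(F)cc3OC)c3ccccc3S2(=O)=O)cc1OC` is a new compound that has not yet been measured. It differs from compound 1 as follows: 2,4-difluoro-6-methoxyphenyl in place of 2-chloro-4-fluorophenyl on a saturated chain carbon bound to an amide-type nitrogen in a ring. Among the compounds with values here, this change resembles the one that led to compound 2, since both replace the 2-chloro-4-fluorophenyl group with a ring carrying a methoxy group and fluorine, though the arrangement on the ring is not the same. Within the data shown here, only one measured step bears on this change, and that step was large and toward stronger binding, so the step expected in this assay is likewise a large drop, estimated as a 50-fold lower number from compound 1 to compound 4 (1.70 log units; beyond the scatter). Compound 4 is therefore estimated to give 0.5 nM, with a likely range from 0.1 nM to 3 nM.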

Compound 4, inhibition constant: 6.31 nM
Compound 4: middle estimate off by 13-fold (1.10 log units), on the low side; the measured number lies above the stated range.
By their numbers in this assay, from the lowest: compound 2; then compound 3; then compound 4; then compound 1.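

The benzyl position is now shown to respond to more than the presence of a methoxy group and fluorine on the ring: in this assay, the change to the 2,4-difluoro-6-methoxyphenyl group gives only a 4.0-fold lower number from compound 1 to compound 4 (0.60 log units; beyond the scatter), a real but modest gain, far smaller than the change to the ring in compound 2. The direct comparison makes the same point, since the two compounds share the core and differ only in this ring, and the 2-chloro-6-fluoro-4-methoxyphenyl group is clearly preferred over the 2,4-difluoro-6-methoxyphenyl group, with a 63-fold higher number from compound 2 to compound 4 (1.80 log units; beyond the scatter). Nothing shown gives a measured explanation for the difference between these two ring patterns.

Two features change together between compound 2 and compound 4, the chlorine and the arrangement of the methoxy group and fluorine on the ring, so these compounds cannot show how much each one contributes. Also open, from the compounds shown here alone, is whether this position would keep its strong binding with an ethoxy group in place of the methoxy group, or with an amine such as dimethylamino on the ring.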